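Adding a methyl to the hydroxy of compound 1

A few compounds are considered here, and "the series" means these few. Any claim that something is new, unique, unknown or untested is made for them only; others in the source may bear on it.

Within the data shown here, in a functional assay on EKVX cells (Homo sapiens) for antiproliferative activity, read by sulforhodamine B assay, with a stated time of 48 h (a higher number here means a weaker inhibitor, a lower number a stronger inhibitor), compound 1 `O=C(NCCCNc1cc(-c2cn(-c3ccccc3)nc2-c2cccc(O)c2)ccn1)Nc1ccc(F)cc1` gives 2740 nM and compound 2 `O=C(NCCCNc1cc(-c2cn(-c3ccccc3)nc2-c2cccc(O)c2)ccn1)Nc1cccc(C(F)(F)F)c1` gives 3500 nM as the only other measured number. Compound 3 `COc1cccc(-c2nn(-c3ccccc3)cc2-c2ccnc(NCCCNC(=O)Nc3ccc(F)cc3)c2)c1` differs from compound 1 by methyl in place of hydrogen on an oxygen on an aromatic ring, which turns 3-hydroxyphenyl into 3-methoxyphenyl. Among the measured compounds shown here, the one measured step (a 1.3-fold higher number from compound 1 to compound 2 (0.11 log units; within the scatter)) lies within the scatter, but it changes a different group, on an amide-type nitrogen. No measurement tests this methyl, so no shift beyond the scatter is expected, in either direction. The expected step is small (a 1.1-fold higher number from compound 1 to compound 3 (0.04 log units; within the scatter)). Compound 3 is estimated at 3000 nM with 1000 nM to 9000 nM as its expected range.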

Compound 3, half-maximal inhibitory concentration: 9630 nM
The estimate for compound 3 lay 3.2-fold (0.51 log units) below the measured number, and the stated range ends below it.
By their numbers in this assay, from the lowest: compounds 1 and 2 (each within the scatter of the next); then compound 3.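

In this assay the change from 3-hydroxyphenyl to 3-methoxyphenyl gives a 3.5-fold higher number from compound 1 to compound 3 (0.55 log units; beyond the scatter) and is the first step shown that lies beyond the scatter. Among these compounds, this position therefore responds to a single methyl on the oxygen, whereas the one earlier step, on an amide-type nitrogen, stayed within the scatter. No measured evidence accounts for this shift. Still open, going by these compounds, is whether a longer chain on the oxygen, such as ethoxy, would move the number further, and how an amine in place of the hydroxy would read.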